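The source may hold more compounds than are shown below. What is called first, only, known or untested is meant among the compounds shown, and "the series" means these compounds.

Measured so far:
- compound 1, `Cc1cccc(NC(=O)Nc2nnc(Sc3ncnc4scc(-c5ccncc5)c34)s2)c1`, 27200 nM
- compound 2, `O=C(Nc1cccc(Cl)c1)Nc1nnc(Sc2ncnc3scc(-c4ccncc4)c23)s1`, 43900 nM
- compound 3, `Cc1ccc(NC(=O)Nc2nnc(Sc3ncnc4scc(-c5ccncc5)c34)s2)cc1`, 17800 nM

All three compounds share one core and differ only in the aryl group on the urea-type nitrogen. In a functional assay on T47D cells (Homo sapiens) for antiproliferative activity, read by MTT assay, with a stated time of 48 h (a lower number here means a stronger inhibitor, a higher number a weaker inhibitor), compound 1 gives 27200 nM, which is the second highest of the three numbers; its two neighbours lie within the scatter on either side, so no order among them can be claimed. Compound 2 carries a chloro in place of methyl on an aromatic carbon, and the step of a 1.6-fold higher number from compound 1 to compound 2 (0.21 log units; within the scatter). Compound 3 carries 4-methylphenyl in place of 3-methylphenyl on an amide-type nitrogen, and the step of a 1.5-fold lower number from compound 1 to compound 3 (0.18 log units; within the scatter). Between those two, the step of a 2.5-fold lower number from compound 2 to compound 3 (0.39 log units; beyond the scatter).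

Compound 4, `O=C(Nc1ccc(Cl)cc1)Nc1nnc(Sc2ncnc3scc(-c4ccncc4)c23)s1`, has not yet been measured. It differs from compound 1 by 4-chlorophenyl in place of 3-methylphenyl on an amide-type nitrogen. Both known steps bear on this change: the chloro-for-methyl swap and the shift from the 3-position to the 4-position each stayed within the scatter, and they pointed in opposite directions, so together no step beyond the scatter in this assay is expected. The expected step is a 1.1-fold higher number from compound 1 to compound 4 (0.04 log units; within the scatter). Compound 4 is therefore estimated at 30000 nM, with a range from 12000 nM to 75000 nM.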

Compound 4, half-maximal inhibitory concentration: 23300 nM
Estimate against measurement, compound 4: 1.3-fold (0.11 log units) above; measured number inside the range.
By their numbers in this assay, from the lowest: compounds 3, 4, 1 and 2 (each within the scatter of the next, the first and the last beyond it).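

In this assay, the place of the chlorine can now be read on its own: going from 3-chlorophenyl to 4-chlorophenyl gives a 1.9-fold lower number from compound 2 to compound 4 (0.28 log units; within the scatter). Exchanging 3-methylphenyl for 4-chlorophenyl alters both the group and its place at once, yet it gives only a 1.2-fold lower number from compound 1 to compound 4 (0.07 log units; within the scatter), so the double change produces no shift that can be told from the scatter. Chloro in place of methyl had been seen only in going from 3-methylphenyl to 3-chlorophenyl; it can now also be read in going from 4-methylphenyl to 4-chlorophenyl, as a 1.3-fold higher number from compound 3 to compound 4 (0.12 log units; within the scatter), and the two readings agree within the scatter: the same change on two cores in this assay, a 1.6-fold higher number (0.21 log units; within the scatter) from compound 1 to compound 2 and a 1.3-fold higher number (0.12 log units; within the scatter) from compound 3 to compound 4, 1.2-fold (0.09 log units) apart, within the scatter of two such steps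

These four compounds carry only a methyl or a chloro on the aryl ring, so they leave open whether a different group there, such as a methoxy, an amine or a carboxylic acid, could move the number much further. They also leave open how a plain phenyl, or a longer chain such as hexyl in place of the aryl ring on the same nitrogen, would read.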